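This account rests on a few compounds, and the source may have more. Where it says the series, first, only, none or still open, it means among the compounds named here.

Measured so far:

- compound 1, `O=C(O)c1ccc(CNC(=O)c2cccc(-c3ccccc3)c2)cc1`: 670 nM
- compound 2, `CC(C)(C)c1ccc(C(=O)NCc2ccc(NC(=O)C(F)(F)F)cc2Cl)cc1`: 14 nM
- compound 3, `C[S+]([O-])c1ccc(CNC(=O)c2ccc(C(C)(C)C)cc2)cc1`: 1300 nM

All three were tested in an assay on HeLa cells with Bile acid receptor (Homo sapiens) as the target, read by a luciferase reporter, with a stated time of 24 h; on this read-out lower numbers stand for an effect already at smaller amounts and higher numbers for an effect only at larger amounts of compound. Among them compound 3 gives the highest number, at 1300 nM. Its nearest neighbour is compound 1 at 670 nM, a difference that lies within the usual scatter, so the two cannot be told apart. Compound 2, at 14 nM, stands far lower, beyond the scatter.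

Compound 4, `CC(=O)Nc1ccc(CNC(=O)c2ccc(C(C)(C)C)cc2)cc1`, has not yet been measured. It differs from compound 3 in one place: a group of 4 heavy atoms (2 carbon, 1 nitrogen, 1 oxygen; no ring) in place of a group of 3 heavy atoms (1 carbon, 1 oxygen, 1 sulfur; no ring), on an aromatic carbon. Going by the values given here, no measured pair shows exactly this change, so its effect can only be guessed from the three values seen. Compound 2, the only one carrying an amide of this kind on the same ring, gives the lowest number, 14 nM, though it also differs elsewhere. Compound 4 is therefore expected to give a lower number than compound 3, with a step of a 4.3-fold lower number from compound 3 to compound 4 (0.64 log units; beyond the scatter) in this assay, while the range must stay wide. The estimate for compound 4 is 300 nM, between 60 nM and 1500 nM.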

Compound 4, half-maximal effective concentration: 2900 nM
For compound 4 the middle estimate is 9.7-fold (0.99 log units) below the measured one; the whole stated range lies below it.
By their numbers in this assay, from the lowest: compound 2; then compounds 1 and 3 (each within the scatter of the next); then compound 4.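

In this assay, placing acetamido on the aromatic carbon para to a large group gives a 2.2-fold higher number from compound 3 to compound 4 (0.35 log units; beyond the scatter) and so brings no drop in the number. Going by these compounds alone, this is the first direct reading of an amide at this position with the rest of the molecule held fixed, and it shows that acetamido alone does not bring the low number seen for compound 2. No measurement here bears on why the step goes this way.

Still open, as far as these compounds go, is how a plain amine or a nitrile at this same place would read on the shared core. Also open is what lies behind the 14 nM of compound 2, since no compound shown separates the chlorine on its ring from the trifluoroacetyl part of its amide.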